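The source may report more compounds than this note shows. Statements on the series, on what has been measured and on what is new or still open speak of the compounds shown alone.

Compound 2 `COc1cc2c(Oc3ccc(NC(=O)c4cc(-c5ccc(F)cc5)on4)cc3)ccnc2cc1OCCCN1CCC(C)CC1` gives 24600 nM in a functional assay on HT-29 cells (Homo sapiens) for antiproliferative activity, read by MTT assay, with a stated time of 72 h (on this read-out higher numbers stand for weaker inhibition and lower numbers for stronger inhibition), the highest of the three numbers here; compound 3 `COc1cc2c(Oc3ccc(NC(=O)C4(c5nnc(-c6ccc(F)cc6)o5)CC4)cc3F)ccnc2cc1OCCCN1CCN(C)CC1` gives 1050 nM and compound 1 `COc1cc2c(Oc3ccc(NC(=O)C4(c5nnc(-c6ccc(F)cc6)o5)CC4)cc3F)ccnc2cc1OCCCN1CCCC1` gives 779 nM in this assay, both well beyond the scatter from compound 2. Within the data shown here, the only single-place step measured, a 1.3-fold higher number from compound 1 to compound 3 (0.13 log units; within the scatter), concerns the amine at the end of the chain and says nothing about the heterocycle. Compound 4 `COc1cc2c(Oc3ccc(NC(=O)c4ncc(-c5ccc(F)cc5)o4)cc3)ccnc2cc1OCCCN1CCC(C)CC1` differs from compound 2 by 5-(4-fluorophenyl)-1,3-oxazol-2-yl in place of 5-(4-fluorophenyl)-1,2-oxazol-3-yl on a carbonyl carbon. Among the measured compounds shown here, no measured pair bears on this change; compounds 1 and 3 differ from compound 2 in several places at once, so no direction can be read from them. The expectation is therefore a step of a 1.2-fold lower number from compound 2 to compound 4 (0.09 log units; within the scatter) of no set direction. For compound 4 the estimate in this assay is 20000 nM, with a range from 5000 nM to 80000 nM.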

Compound 4, half-maximal inhibitory concentration: 1890 nM
For compound 4 the middle estimate is 11-fold (1.02 log units) above the measured one; measured number below the stated range.
By their numbers in this assay, from the lowest: compounds 1, 3 and 4 (each within the scatter of the next, the first and the last beyond it); then compound 2.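

The move from 5-(4-fluorophenyl)-1,2-oxazol-3-yl to 5-(4-fluorophenyl)-1,3-oxazol-2-yl on the carbonyl carbon gives a 13-fold lower number from compound 2 to compound 4 (1.11 log units; beyond the scatter) in this assay and so shows that this position responds strongly to how the ring atoms are joined, even with the same atoms and the same counted donors and acceptors. The earlier single-place step concerned only the chain amine. No measurement at hand accounts for this step. Open, as far as these compounds go, is whether 5-(4-fluorophenyl)-1,3-thiazol-2-yl on this carbonyl carbon would track the 1,3-oxazole, and whether the step persists with a morpholine on the chain.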